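The compounds below may be only part of what the source reports. "The series", "measured", "known", "first", "only" and "open" are said of these compounds alone.

Compound 2 `C#CCN(CC#C)Cc1cn(-c2cc(NC(=S)NCC)ncn2)cn1` has the higher of the two measured numbers in an assay on isolated protein for inhibition of Amine oxidase [flavin-containing] B (Homo sapiens), read by fluorescence and Amplex Red, with a stated time of 15 min, tested at 50 uM; a higher number here means more inhibition at the concentration tested (going by the name of the read-out), a lower number less inhibition: there compound 2 gives 42.1%, whereas compound 1 `C#CCN(Cc1cn(-c2cc(NC(=S)NCC)ncn2)cn1)C(C)=O` gives 1.17%. Among the compounds with values here, the only measured step, a number 40.9 percentage points higher from compound 1 to compound 2 (beyond the scatter), describes propargyl in place of acetyl on an amine nitrogen. The unmeasured compound 3 `C#CCNCCCc1cn(-c2cc(NC(=S)NCC)ncn2)cn1` differs from compound 2 in one place: 2-(propargylamino)ethyl in place of dipropargylamino on a saturated chain carbon bound to an aromatic carbon. The step from compound 1 to compound 2 bears on this change only in part, since it shows that the presence of the dipropargylamino group goes with a large gain, while compound 3 keeps one propargyl and a hydrogen-bond donor on the nitrogen rather than losing the propargyl group entirely. Within the data shown here, no measured pair shows what lengthening the chain by itself does. The expectation is therefore a moderate loss in this assay, but not a fall to the level of compound 1, and compound 3 is estimated at 30%, within 5% to 60%, which corresponds to an expected step of a number 12.1 percentage points lower from compound 2 to compound 3 (beyond the scatter).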

Compound 3, a percentage reported as inhibition, at one concentration (the size of the read-out at that concentration, not a potency): 36.6%
For compound 3 the middle estimate is 6.6 percentage points below the measured one, and the stated range covers the measured number.
By their numbers in this assay, from the lowest: compound 1; then compounds 3 and 2 (each within the scatter of the next).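

The change to 2-(propargylamino)ethyl on a saturated chain carbon bound to an aromatic carbon gives a number 5.5 percentage points lower from compound 2 to compound 3 (within the scatter) in this assay, so at this position the second propargyl group of dipropargylamino is not required to keep the inhibition read-out at this level. The same holds for a group with one triple bond and a hydrogen-bond donor on the nitrogen, which stands level with dipropargylamino despite the different chain. Compound 1 stays apart with a number 35.4 percentage points higher from compound 1 to compound 3 (beyond the scatter), which shows that the large gain first seen with compound 2 does not depend on having two propargyl groups, and nothing available gives a reason for either step.

The step to compound 3 alters the chain and the groups on the nitrogen together, so the contribution of each stays unresolved, and a simple propargylamino group on the shorter chain, or a methyl in place of the hydrogen on the nitrogen of compound 3, would separate them. Going by these compounds, all of these numbers come from a single concentration, so how the compounds compare in potency also remains open.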